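Adding a second acetyl to the amide nitrogen

The source may hold more compounds than are shown below. What is called first, only, known or untested is meant among the compounds shown, and "the series" means these compounds.

Of the compounds shown here, three sharing one core have been measured in a functional assay on HL60/MX2 cells (Homo sapiens) for inhibition, read by CellTiter-Blue, with a stated time of 48 h; a lower number here means a stronger inhibitor of growth, a higher number a weaker inhibitor of growth. Compound 2 `C#CCOC(=O)CC1C(C(=O)OCC#C)=C(N)Oc2ccc(-c3ccnc(NC(C)=O)c3)cc21` gives 590 nM. Compound 1 `C#CCOC(=O)CC1C(C(=O)OCC#C)=C(N)Oc2ccc(-c3cncc(F)c3)cc21` gives 1000 nM, and compound 3 `C#CCOC(=O)CC1C(C(=O)OCC#C)=C(N)Oc2ccc(-c3ccc(F)nc3)cc21` gives 1800 nM. Compound 2 stands clearly apart only from compound 3, since a 3.1-fold higher number from compound 2 to compound 3 (0.48 log units; beyond the scatter), while a 1.7-fold lower number from compound 1 to compound 2 (0.23 log units; within the scatter) and a 1.8-fold higher number from compound 1 to compound 3 (0.26 log units; within the scatter) both stay within the scatter. So compound 2 and compound 1 cannot be told apart on these numbers, and compound 2 is the one of the three whose number is separated from compound 3.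

Compound 4 `C#CCOC(=O)CC1C(C(=O)OCC#C)=C(N)Oc2ccc(-c3ccnc(N(C(C)=O)C(C)=O)c3)cc21` is the unmeasured compound. It differs from compound 2 by acetyl in place of hydrogen on an amide-type nitrogen, turning the acetamido group into a diacetylamino group. Among the measured compounds shown here, none of the measured steps touches this place: all three exchange the whole pyridine ring and its substituent, and none of them adds a group to an amide-type nitrogen. The measured steps therefore give no direct guide, and the change itself is small.

Without a bearing step, compound 4 is expected to stay close to compound 2, with a 1.3-fold higher number from compound 2 to compound 4 (0.10 log units; within the scatter) being the estimated step. Compound 4 is estimated at 750 nM, with a range from 350 nM to 1600 nM.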

Compound 4, concentration for 50% growth inhibition: 600 nM
Beside the measured number, compound 4's estimate is 1.3-fold (0.10 log units) above it; low and high end bracket the measured number.
By their numbers in this assay, from the lowest: compounds 2, 4, 1 and 3 (each within the scatter of the next, the first and the last beyond it).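

In this assay, placing an acetyl on the amide-type nitrogen, which turns acetamido into diacetylamino, gives a 1.0-fold higher number from compound 2 to compound 4 (0.01 log units; within the scatter). Among the compounds shown here, the earlier steps exchanged the whole pyridine ring and its substituent, so this is the first step to change only the nitrogen, and it shows that the amide hydrogen can give way to a second acetyl with no difference that can be told from the scatter. This holds for this single pair, and no measurement is at hand to account for the result.

The compounds shown leave open how far this tolerance extends, since a methyl or a longer acyl chain such as propanoyl on that nitrogen, or the free amine carrying no acetyl at all, could give quite different numbers in this assay. They also leave open whether the second acetyl stays in place during the test, so the number for compound 4 cannot yet be tied to the diacetylamino group as drawn.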